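The source may hold more compounds than are shown below. What is called first, only, known or untested is meant among the compounds shown, and "the series" means these compounds.

Measured compounds:

Compound 1 `Cn1ccc(-c2cccc3c2CCC3c2ncc[nH]2)n1`. In a functional assay on CHO cells for agonist activity at Alpha-1D adrenergic receptor (Homo sapiens), read by FLIPR and calcium flux (on this read-out lower numbers stand for an effect already at smaller amounts and higher numbers for an effect only at larger amounts of compound), compound 1 gives > 10000 nM, a limit of the assay and not a number.
Compound 2 `c1cncc(-c2cccc3c2CCC3c2ncc[nH]2)c1`. In this assay compound 2 gives > 10000 nM, again a limit.
Compound 3 `Cc1oncc1-c1cccc2c1CCC2c1ncc[nH]1`. In this assay compound 3 gives > 10000 nM, also a limit.

Compound 3 thus stands where every measured member of the series stands: at the limit of > 10000 nM in this assay, at which 3 of the 3 values shown sit. None of the three steps among them can be read, neither a step that the two limits leave unreadable from compound 1 to compound 2, nor a step that the two limits leave unreadable from compound 1 to compound 3, nor a step that the two limits leave unreadable from compound 2 to compound 3, since both ends of each are limits.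

Compound 4 `CCS(=O)(=O)Nc1cccc2c1CCC2c1ncc[nH]1` differs from compound 3 by (ethylsulfonyl)amino in place of 5-methyl-1,2-oxazol-4-yl on an aromatic carbon. Within the data shown here, no measured step covers an exchange of this kind, and no measured compound shows a number in this assay at all; the three limits give no direction and no size for the step from compound 3 to compound 4. The expectation therefore rests only on the shared core and the three limits: compound 4 is expected at a step that the limit leaves unreadable from compound 3 to compound 4, most likely once more reported as a limit. The estimate for compound 4 in this assay is 15000 nM, expected within 3000 nM to 60000 nM.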

Compound 4, half-maximal effective concentration: > 10000 nM
Compound 4: only a limit was reported; the forecaster's own chance of this, stated with the estimate: 80%; the middle value is on the limit's open side.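

In this assay compound 4 gives > 10000 nM as a limit, not a number. No new step can be read from compound 4 to compounds 1, 2 or 3, because all four values are limits: the limit of > 10000 nM in this assay, at which 4 of the 4 values shown sit.

The compounds shown leave open whether any group at this place on the shared core gives a measurable effect in this assay at all.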